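The source may hold more compounds than are shown below. What is called first, only, known or untested is meant among the compounds shown, and "the series" means these compounds.

Compound 1 `Cc1c(OCCCCOc2ccc(C(=O)O)cc2)ccc(C(=O)CC(C)C)c1O`: 122 nM
Compound 2 `CCC(=O)c1ccc(OCCCCOc2ccc(F)c(C(=O)O)c2)c(C)c1O`: 124 nM
Compound 3 `Cc1c(OCCCCOc2ccc(C(=O)O)cc2)ccc(C(=O)CC2CCCC2)c1O`: 824 nM

Of the compounds shown here, three have been measured in an assay on HEK293 cells for positive allosteric modulation of metabotropic glutamate receptor 2 (Rattus norvegicus), read by thallium flux, with a stated time of 2.5 min; on this read-out lower numbers stand for an effect already at smaller amounts and higher numbers for an effect only at larger amounts of compound. Compound 3 gives the highest of the three numbers; its nearest neighbour is compound 2, lower by a step beyond the scatter, and the distance to compound 1 is a little larger still. For the measured compounds named here, the only one-place step among the measured set, a 6.8-fold higher number from compound 1 to compound 3 (0.83 log units; beyond the scatter), concerns the saturated chain carbon bound to the carbonyl carbon and carries no information about the aromatic ring.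

Compound 4 `Cc1c(OCCCCOc2ccc(C(=O)O)cc2F)ccc(C(=O)CC2CCCC2)c1O` follows from compound 3 by fluoro in place of hydrogen on an aromatic carbon. Going by the values given here, no measured step isolates this change. Compound 2 also carries a fluoro on the ring bearing the carboxy group, and its number in this assay sits close to that of compound 1, yet the two compounds differ in the chain as well, so the comparison is indirect. The expectation is therefore a step of a 1.1-fold lower number from compound 3 to compound 4 (0.04 log units; within the scatter), not beyond the scatter. Compound 4 is estimated at 750 nM, within 300 nM to 1900 nM.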

Compound 4, half-maximal effective concentration: 639 nM
Compound 4: the middle estimate sits 1.2-fold (0.07 log units) above what was measured; low and high end bracket the measured number.
By their numbers in this assay, from the lowest: compounds 1 and 2 (each within the scatter of the next); then compounds 4 and 3 (each within the scatter of the next).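

In this assay, for the compounds shown here, the change from 4-carboxyphenyl to 4-carboxy-2-fluorophenyl gives a 1.3-fold lower number from compound 3 to compound 4 (0.11 log units; within the scatter), the first direct reading of fluoro in place of hydrogen on this aromatic carbon, ortho to a large group and meta to a carboxy group. The two numbers cannot be told apart, so with the cyclopentyl group in the chain, this position accepts a fluoro without a step beyond the scatter. No measurement shown here offers a reason for this result.

From the compounds shown here alone, whether fluoro behaves the same way alongside the isopropyl group of compound 1 remains open. So does the outcome with a larger group at this place, such as chloro, methoxy or an amine, which could show how much room for change the position really has.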